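Methyl for bromo on two enone cores

This account rests on a few compounds, and the source may have more. Where it says the series, first, only, none or still open, it means among the compounds named here.

Compound 1 `O=C1/C(=C/c2cccc(Br)c2)Cc2ccccc21` and compound 2 `Cc1cccc(/C=C2\Cc3ccccc3C2=O)c1` share one core; compound 3 `O=C1CCCCC/C1=C\c1cccc(Br)c1` and the unmeasured compound 4 `Cc1cccc(/C=C2\CCCCCC2=O)c1` share another. The difference between the two cores is not broken down here.

In a functional assay on CCRF-CEM cells (Homo sapiens) for inhibition (a higher number here means a weaker inhibitor, a lower number a stronger inhibitor), compound 1 gives 32400 nM. In this assay compound 2 gives 41300 nM. In this assay compound 3 gives 137000 nM, the highest of the three numbers; its gaps to compound 2 and to compound 1 both lie beyond the usual scatter, so compound 3 is the weakest inhibitor of the three measured.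

The change from compound 1 to compound 2 is methyl in place of bromo on an aromatic carbon and made the step of a 1.3-fold higher number from compound 1 to compound 2 (0.11 log units; within the scatter). The change from compound 3 to compound 4 is methyl in place of bromo on an aromatic carbon. It is the same kind of change, on a different core: the first place is given as "meta to a large group", the second as "meta to a group of 9 heavy atoms".

Going by the values given here, for compound 4 a step of a 1.2-fold higher number from compound 3 to compound 4 (0.09 log units; within the scatter) is expected, because a 1.3-fold higher number from compound 1 to compound 2 (0.11 log units; within the scatter) is the only measured instance of this change. Compound 4 is thus estimated at 170000 nM, within 85000 nM to 340000 nM.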

Compound 4, half-maximal inhibitory concentration: 170000 nM
Compound 4: the middle estimate sits on the measured number at the digits printed; the measured number falls inside the stated range.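

In this assay the new step, a 1.2-fold higher number from compound 3 to compound 4 (0.09 log units; within the scatter), shows no readable effect of methyl in place of bromo on the core of compound 3. Set beside the earlier step, the change carries from one core to the other with no detectable difference: the same change on two cores in this assay, a 1.3-fold higher number (0.11 log units; within the scatter) from compound 1 to compound 2 and a 1.2-fold higher number (0.09 log units; within the scatter) from compound 3 to compound 4, 1.0-fold (0.01 log units) apart, within the scatter of two such steps

This holds only for this one change, at this one place on the aromatic ring, across two pairs of compounds on two cores; neither step lies beyond the scatter, so the agreement is between two null results and does not show that a step of real size would carry across cores in the same way, nor does it say how any further core would respond.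

The compounds shown leave open whether a group of another kind at this place, such as an amine, a carboxylic acid or a longer chain, would move the number on either core. They also leave open whether the two cores would still track each other for such a group.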